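The compounds below may be only part of what the source reports. "The series", "measured", "known", "first", "only" and "open" are said of these compounds alone.

Two compounds have been measured in a functional assay on PC-3M cells (Homo sapiens) for antiproliferative activity, read by microscopy, with a stated time of 24 h; a higher number here means a weaker inhibitor, a lower number a stronger inhibitor:
Compound 1 `COc1ccc(Cn2c(-c3ccccc3)c(-c3ccccc3)c3c(=N)n(CCCO)cnc32)cc1` gives 2170 nM; 2140 nM (2 entries).
Compound 2 `COc1ccc(-c2c(-c3ccc(OC)cc3)n(Cc3ccccc3)c3ncn(CC4CCOC4)c(=N)c23)cc1` gives > 20000 nM.

Compound 1 is the only one of the two with a numeric result, and its repeated entries agree closely (the several entries of compound 1 in this assay, 2170 nM; 2140 nM (2 entries)). For compound 2 the reading is a limit of the assay, not a number (the limit of > 20000 nM in this assay, at which 1 of the 2 values shown sits). Compound 2 therefore stands at the weak end of what this assay can report, with no exact value behind it.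

Compound 3 `COc1ccc(-c2c(-c3ccc(OC)cc3)n(Cc3ccccc3)c3ncn(C4CCOCC4)c(=N)c23)cc1` is built from compound 2 by a single change: oxan-4-yl in place of (oxolan-3-yl)methyl on an aromatic nitrogen. The two groups have the same atoms, joined differently, so the overall size of the molecule stays the same. Among the compounds with values here, no step between two measured compounds with a change of this kind is available, so there is no measured precedent for how large its effect might be. With compound 2 already at the limit, the step that the limit leaves unreadable from compound 2 to compound 3 is expected to stay within the scatter, with no movement back into the measurable range. Compound 3 is expected to give roughly 25000 nM, within a range from 8000 nM to 80000 nM, most likely reported again as a limit.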

Compound 3, half-maximal inhibitory concentration: > 20000 nM
Compound 3: no number, only a limit; the forecaster's own chance of this, stated with the estimate: 75%; the middle value is on the limit's open side.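

In this assay compound 3 gives > 20000 nM, which is a limit and not a number. Compound 2 is also reported only as a limit, so no step can be read between compound 2 and compound 3. On these data alone, whether oxan-4-yl and (oxolan-3-yl)methyl differ in their effect on activity remains open.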